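This account rests on a few compounds, and the source may have more. Where it says the series, first, only, none or still open, it means among the compounds named here.

**Measured so far**
- compound 1 `CC[C@H](NC(=O)[C@H](COC)NC(=O)c1cc(C)on1)C(=O)N[C@@H](CC(C)C)C(=O)[C@@]1(C)CO1`: 468 nM
- compound 2 `COC[C@H](NC(=O)c1cc(C)on1)C(=O)N[C@H](C(=O)N[C@@H](CC(C)C)C(=O)[C@@]1(C)CO1)C(C)C`: 636 nM

Among the measured compounds shown here, in a functional assay on MES-SA cells (Homo sapiens) for cytotoxicity, read by luminescence and CellTiter-Glo, with a stated time of 72 h (on this read-out lower numbers stand for stronger inhibition and higher numbers for weaker inhibition), compound 2 at 636 nM lies within the scatter of compound 1, the only other measured compound. Compound 3 `COC[C@H](NC(=O)c1cc(C)on1)C(=O)N[C@@H](C)C(=O)N[C@@H](CC(C)C)C(=O)[C@@]1(C)CO1` has methyl in place of isopropyl on a saturated chain carbon bound to an amide-type nitrogen and a carbonyl carbon. For the measured compounds named here, the one measured step bearing on this, methyl in place of hydrogen on a saturated chain carbon bound to two saturated chain carbons, gave a 1.4-fold higher number from compound 1 to compound 2 (0.13 log units; within the scatter) and stayed within the scatter. On that single step, no change beyond the scatter is expected in this assay in either direction. The expected step is a 1.2-fold lower number from compound 2 to compound 3 (0.06 log units; within the scatter) on this estimate. For compound 3 the estimated value is 550 nM with an expected range of 230 nM to 1300 nM in this series.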

Compound 3, half-maximal inhibitory concentration: 276 nM
Compound 3: middle estimate off by 2.0-fold (0.30 log units), on the high side; low and high end bracket the measured number.
By their numbers in this assay, from the lowest: compounds 3, 1 and 2 (each within the scatter of the next, the first and the last beyond it).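

In this assay, among the compounds shown here, methyl in place of isopropyl on a saturated chain carbon bound to an amide-type nitrogen and a carbonyl carbon gives a 2.3-fold lower number from compound 2 to compound 3 (0.36 log units; beyond the scatter) and is the only step beyond the scatter. Hydrogen in place of methyl on a saturated chain carbon, two bonds along the chain from that nitrogen and carbonyl carbon, gives a 1.7-fold lower number from compound 1 to compound 3 (0.23 log units; within the scatter) and stays within it. No supporting evidence bears on this result. Open, as far as these compounds go, is how a hydroxymethyl group or a primary amine on this carbon would read, as well as hydrogen in place of the methyl of compound 3.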